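A few compounds are considered here, and "the series" means these few. Any claim that something is new, unique, unknown or untested is made for them only; others in the source may bear on it.

Three compounds share one core and differ only at a single aromatic carbon of a fused two-ring system. Compound 1 `COc1ccc(F)cc1CNCCCNc1ccnc2cc(C3CCCCC3)ccc12` carries cyclohexyl there, compound 2 `COc1ccc(F)cc1CNCCCNc1ccnc2cc(-c3cccc4ccccc34)ccc12` carries naphthalen-1-yl, and compound 3 `COc1ccc(F)cc1CNCCCNc1ccnc2cc(CC3CCCCC3)ccc12` carries cyclohexylmethyl. In a physicochemical assay for acid dissociation, compound 1 gives 9.47, compound 2 gives 9.47, and compound 3 gives 9.47. Compound 3 stands level with both of the others: the step of no change at the digits printed from compound 1 to compound 3 (within the scatter) and the step of no change at the digits printed from compound 2 to compound 3 (within the scatter) lie within the scatter, as does no change at the digits printed from compound 1 to compound 2 (within the scatter). Compound 4 `COc1ccc(F)cc1CNCCCNc1ccnc2cc(-c3ccc(C(F)(F)F)cc3)ccc12` differs from compound 3 in one place: 4-(trifluoromethyl)phenyl in place of cyclohexylmethyl on an aromatic carbon. Within the data shown here, the steps that bear on this change are the two leading into compound 3, and neither moved this assay beyond the scatter, although none of the measured compounds has an aromatic ring bearing trifluoromethyl at that carbon. Because no change at the digits printed from compound 2 to compound 3 (within the scatter) was flat even when an aromatic ring stood at that carbon, compound 4 is expected to stay level with compound 3. The expected step is no change at the digits printed from compound 3 to compound 4 (within the scatter), none beyond the scatter. Compound 4 is estimated at 9.47, with a range from 9.2 to 9.75.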

Compound 4, acid dissociation constant: 9.47
The estimate for compound 4 equals the measured number at the digits printed; the measured number falls inside the stated range.
By their numbers in this assay, from the lowest: compounds 1, 2, 3 and 4 (each within the scatter of the next).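

In this assay, the series now includes an aromatic ring bearing trifluoromethyl at this carbon, and the read-out still shows no change at the digits printed from compound 3 to compound 4 (within the scatter), no change at the digits printed from compound 2 to compound 4 (within the scatter) and no change at the digits printed from compound 1 to compound 4 (within the scatter). Among these compounds, this change brings fluorine into the group at this position for the first time, and the entering group has more heavy atoms than cyclohexylmethyl, yet all four compounds remain within the scatter of one another. No supporting data are available to account for this level result.

The compounds shown leave open whether an amine, a carboxylic acid or a nitrile at this aromatic carbon would also stay level with compound 4 in this assay. They also leave open whether a change elsewhere on the shared core would move this read-out.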